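Removing a Fluorine from an Inactive Benzylamide Series

The source may hold more compounds than are shown below. What is called first, only, known or untested is meant among the compounds shown, and "the series" means these compounds.

Compound 1 `CN(Cc1ccccc1)C(=O)C1CCN(C(=O)c2ccc(S(C)(=O)=O)c([N+](=O)[O-])c2)CC1`: in an assay on isolated protein for inhibition of vitamin D3 receptor (Homo sapiens), read by fluorescence polarization (a lower number here means a stronger inhibitor, a higher number a weaker inhibitor), compound 1 gives > 60000 nM, a limit of the assay.
Compound 2 `CN(Cc1ccccc1F)C(=O)CNC(=O)c1ccc(S(C)(=O)=O)c([N+](=O)[O-])c1`: in this assay compound 2 gives > 60000 nM, again a limit.
Compound 3 `CN1CCN(C(=O)C2CCN(C(=O)c3ccc(S(C)(=O)=O)c([N+](=O)[O-])c3)CC2)CC1`: in this assay compound 3 gives > 60000 nM, also a limit.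

Compound 2 therefore stands at the limit of this assay, and every value shown sits at that same limit (the limit of > 60000 nM in this assay, at which 3 of the 3 values shown sit), so nothing separates it from compound 1 or compound 3 on the numbers.

Compound 4 `CN(Cc1ccccc1)C(=O)CNC(=O)c1ccc(S(C)(=O)=O)c([N+](=O)[O-])c1` differs from compound 2 by one change: hydrogen in place of fluoro on an aromatic carbon. It is hydrogen in place of fluoro on an aromatic carbon, read one bond further out as 2-fluorobenzyl to benzyl.

Among the measured compounds shown here, only one measured step exists, a step that the two limits leave unreadable from compound 1 to compound 3, and it is unreadable, since both ends lie at the limit. It concerns a different position and does not bear on the change in compound 4. With no readable step at all, and every compound at the limit, the expected step that the limit leaves unreadable from compound 2 to compound 4 is none beyond the scatter, and compound 4 is expected to remain at the limit of this assay.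

Compound 4 is estimated at 100000 nM, with a range from 30000 nM to 300000 nM.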

Compound 4, half-maximal inhibitory concentration: > 60000 nM
Compound 4 ended at the assay's limit (the forecaster's own chance of this, stated with the estimate: 88%); the middle value does not contradict the limit.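

In this assay compound 4 gives > 60000 nM, a limit of the assay, so no step can be read for 2-fluorobenzyl to benzyl between compound 2 and compound 4. The series offers no separation at all: the limit of > 60000 nM in this assay, at which 4 of the 4 values shown sit. The compounds shown leave open what effect, if any, this change has on inhibition, and which structure would give a readable value in this assay.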